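The source may report more compounds than this note shows. Statements on the series, on what has been measured and on what is new or still open speak of the compounds shown alone.

Compound 3 `CNC(=O)c1cccc(NC(=O)[C@H]2CCCN2C(=O)C2(c3cccc(Cl)c3)CCCC2)c1` gives 1260 nM in an assay on isolated protein for inhibition of histone acetyltransferase p300 (Homo sapiens), with a stated time of 60 min (on this read-out higher numbers stand for weaker inhibition and lower numbers for stronger inhibition), the highest of the three numbers; compound 1 `O=C(Nc1ccc2[nH]c(=O)[nH]c2c1)[C@H]1CCCN1C(=O)C1(c2cccc(Cl)c2)CCCC1` gives 0.398 nM and compound 2 `O=C(Nc1cnc2[nH]ncc2c1)[C@H]1CCCN1C(=O)C1(c2cccc(Cl)c2)CCCC1` gives 15.9 nM. Compound 4 `O=C(Nc1ccc(O)cc1)[C@H]1CCCN1C(=O)C1(c2cccc(Cl)c2)CCCC1` carries 4-hydroxyphenyl in place of 3-(methylcarbamoyl)phenyl on an amide-type nitrogen. Among the compounds with values here, the steps that bear on this place are a 3200-fold higher number from compound 1 to compound 3 (3.50 log units; beyond the scatter) and a 79-fold higher number from compound 2 to compound 3 (1.90 log units; beyond the scatter), both large, and a 40-fold higher number from compound 1 to compound 2 (1.60 log units; beyond the scatter); every change here moved the number far. Within the data shown here, no measured step exchanges one all-carbon ring for another, so the direction for compound 4 is open. Compound 4 is expected to stay close to compound 3, with the estimated step of a 2.1-fold lower number from compound 3 to compound 4 (0.32 log units; beyond the scatter) and an estimated value of 600 nM, ranging from 60 nM to 6000 nM.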

Compound 4, half-maximal inhibitory concentration: 0.631 nM
Beside the measured number, compound 4's estimate is 950-fold (2.98 log units) above it; the whole stated range lies above it.
By their numbers in this assay, from the lowest: compounds 1 and 4 (each within the scatter of the next); then compound 2; then compound 3.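

In this assay, 4-hydroxyphenyl in place of 3-(methylcarbamoyl)phenyl on the amide-type nitrogen gives a 2000-fold lower number from compound 3 to compound 4 (3.30 log units; beyond the scatter), so a single all-carbon aromatic ring at this place need not cost potency. A second ring is not required here: a 1.6-fold higher number from compound 1 to compound 4 (0.20 log units; within the scatter) stays within the scatter, while a 25-fold lower number from compound 2 to compound 4 (1.40 log units; beyond the scatter) is large. Nothing shown gives a reason for these steps.

On these data alone, what plain phenyl, 4-methoxyphenyl or 4-aminophenyl would give on this nitrogen stays open. So does how 3-hydroxyphenyl would compare with 4-hydroxyphenyl.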